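A few compounds are considered here, and "the series" means these few. Any claim that something is new, unique, unknown or untested is made for them only; others in the source may bear on it.

Measured compounds in a functional assay on K562/Adr cells (Homo sapiens) for inhibition, read by MTT assay, with a stated time of 48 h, tested at 30 uM; on this read-out lower numbers stand for less inhibition and higher numbers for more inhibition at the one concentration tested (going by the name of the read-out):
compound 1, `Nc1nc2ccc(-c3cn([C@@H]4CN[C@H](C(=O)Nc5ccc(Cl)cc5Cl)C4)nn3)nc2s1`, gives 42.2%;
compound 2, `Nc1nc2ccc(-c3cn([C@@H]4CN[C@H](C(=O)Nc5ccc(Br)cc5)C4)nn3)nc2s1`, gives 35.9%;
compound 3, `Nc1nc2ccc(-c3cn([C@@H]4CN[C@H](C(=O)Nc5ccc(F)c(F)c5)C4)nn3)nc2s1`, gives 27.4%.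

Compound 3 sits lowest of these three numbers, though only its gap to compound 1, a number 14.8 percentage points lower from compound 1 to compound 3 (beyond the scatter), is beyond the scatter; the gap a number 8.5 percentage points lower from compound 2 to compound 3 (within the scatter) is within it. Compound 4, `O=C(Nc1nc2ccc(-c3cn([C@@H]4CN[C@H](C(=O)Nc5ccc(F)c(F)c5)C4)nn3)nc2s1)C1CC1`, differs from compound 3 by cyclopropylcarbonyl in place of hydrogen on a nitrogen on an aromatic ring. The three measured steps all alter the aryl group on the amide-type nitrogen, so none of them bears on a change at the amino group on the aromatic ring; the data give no guide here. With nothing to point either way, a step of a number 0.4 percentage points lower from compound 3 to compound 4 (within the scatter) is expected, not beyond the scatter, and compound 4 is estimated at 27%, in the range 10% to 45%.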

Compound 4, a percentage reported as inhibition, at one concentration (the size of the read-out at that concentration, not a potency): 29.5%
For compound 4 the middle estimate is 2.5 percentage points below the measured one, within the range that was stated.
By their numbers in this assay, from the lowest: compounds 3, 4, 2 and 1 (each within the scatter of the next, the first and the last beyond it).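

Cyclopropylcarbonyl on the nitrogen on the aromatic ring is the first change shown away from the aryl group on the amide-type nitrogen, and in this assay the result is a number 2.1 percentage points higher from compound 3 to compound 4 (within the scatter). With the 3,4-difluorophenyl amide in place, this nitrogen therefore carries the added acyl group without a shift beyond the scatter. Nothing measured here bears on why the reading holds. Open, going by these compounds, is whether an acetyl group, or a longer acyl chain ending in an amine, would read the same here, and whether cyclopropylcarbonyl would behave alike on compound 1.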